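A few compounds are considered here, and "the series" means these few. Any claim that something is new, unique, unknown or untested is made for them only; others in the source may bear on it.

Measured so far in an ADME assay on NCM460 cells (Homo sapiens) for cytotoxicity, read by CCK-8 assay, with a stated time of 48 h; a higher number here means a weaker inhibitor, a lower number a stronger inhibitor:
compound 1 `COc1ccc(/C=C\c2cc(OC)c(OC)c(OC)c2)cc1OCc1ccc(C=O)cc1`: 41000 nM
compound 2 `COc1ccc(/C=C\c2cc(OC)c(OC)c(OC)c2)cc1OCc1ccc(CN2C[C@H](O)C[C@@H]2C(=O)O)cc1`: > 50000 nM (a limit)
compound 3 `COc1ccc(/C=C\c2cc(OC)c(OC)c(OC)c2)cc1OCc1ccc(CN2CCCC[C@@H]2C(=O)O)cc1`: > 50000 nM (a limit)

Compound 3 has no number here, only a limit, and compound 2 likewise has only a limit. Together they make up (the limit of > 50000 nM in this assay, at which 2 of the 3 values shown sit).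

Next in the series is compound 4 `COc1ccc(/C=C\c2cc(OC)c(OC)c(OC)c2)cc1OCc1ccc(CN2CCCCC2C(=O)O)cc1`. The change is the two compounds have the same atoms and bonds; at least one stereo element is drawn with a configuration in one of them and without one in the other: 1 of 2 stereo elements differ; a stereocentre at a saturated ring carbon is drawn R in compound 3 and without a configuration in compound 4. The two compounds have the same atoms and bonds, and a stereocentre at a saturated ring carbon is drawn R in compound 3 and without a configuration in compound 4.

Going by the values given here, no measured step covers a change of this kind, so the nearest evidence is indirect. Putting (2-carboxy-4-hydroxypyrrolidin-1-yl)methyl in place of formyl gave an at least 1.2-fold higher number from compound 1 to compound 2 (0.08 log units; that floor lies within the scatter). Putting (2-carboxypiperidin-1-yl)methyl in place of formyl gave an at least 1.2-fold higher number from compound 1 to compound 3 (0.08 log units; that floor lies within the scatter). Between the two carboxylic acids the data show a step that the two limits leave unreadable from compound 2 to compound 3.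

The expectation rests mainly on compound 3, whose > 50000 nM is a limit. No step beyond the scatter is expected in this assay, and the estimated step is a step that the limit leaves unreadable from compound 3 to compound 4. Compound 4 is expected to read 60000 nM, with an estimated range from 35000 nM to 120000 nM, and the assay will most likely report only a limit.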

Compound 4, half-maximal inhibitory concentration: > 50000 nM
Compound 4: only a limit was reported; the forecaster's own chance of this, stated with the estimate: 85%; the middle value does not contradict the limit.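

In this assay, going by these compounds alone, compound 4 gives > 50000 nM, which is a limit and not a number, and the only change from its neighbour is one of drawn stereochemistry: the fact that one of compounds 3 and 4 is drawn with a defined configuration and the other without, at the place where they differ. Putting (2-carboxypiperidin-1-yl)methyl in place of formyl gave an at least 1.2-fold higher number from compound 1 to compound 4 (0.08 log units; that floor lies within the scatter), so the form with no drawn configuration at the saturated ring carbon also shows no change that can be claimed against the formyl compound. The steps to compound 4 from compound 3 and from compound 2 cannot be read, so any effect of the stereocentre stays hidden at the top of the measured range: the limit of > 50000 nM in this assay, at which 3 of the 4 values shown sit.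

As far as these compounds go, how the drawn and undrawn forms of the stereocentre would compare stays open, as neither gives a number. Also open, from the compounds shown here alone, is whether a methyl ester in place of the carboxylic acid, or a morpholine ring in place of the 2-carboxypiperidin-1-yl group, would give a reading under the limit in this assay.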